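A few compounds are considered here, and "the series" means these few. Any claim that something is new, unique, unknown or untested is made for them only; others in the source may bear on it.

Measured so far:
compound 1, `O=C(CN(c1nc(Cl)nc2[nH]cnc12)C1CC1)N[C@@H](CC(=O)OCc1ccccc1)C(=O)OCc1ccccc1`: 22.4%
compound 2, `CC(C)[C@H](NC(=O)CN(c1nc(Cl)nc2[nH]cnc12)C1CC1)C(=O)OCc1ccccc1`: 55.5%

In a functional assay on the whole organism (Tail, strain ICR) with Mus musculus as the target, in the tail flick test, with a stated time of 60 min, at a dose of 25 umol/kg by the oral route (a lower number here means a weaker effect, a higher number a stronger effect of the compound at the dose given), compound 2 stands highest of the two numbers; its nearest neighbour is compound 1, which lies a number 33.1 percentage points higher from compound 1 to compound 2 (beyond the scatter). Compound 3, `NC(=O)C[C@H](NC(=O)CN(c1nc(Cl)nc2[nH]cnc12)C1CC1)C(=O)OCc1ccccc1`, is the next structure: carbamoylmethyl in place of isopropyl on a saturated chain carbon bound to an amide-type nitrogen and a carbonyl carbon. Within the data shown here, only the step from compound 1 to compound 2 bears on it, and it was large. Carbamoylmethyl is not the group that compound 1 carries, so that step can only loosely guide the expectation. A downward step is expected, a number 20.5 percentage points lower from compound 2 to compound 3 (beyond the scatter), and compound 3 is estimated at 35%, between 15% and 55%.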

Compound 3, a percentage reported as activity, at one dose (the size of the read-out at that dose, not a potency): 36.4%
Compound 3: middle estimate off by 1.4 percentage points, on the low side; low and high end bracket the measured number.
By their numbers in this assay, from the lowest: compound 1; then compound 3; then compound 2.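

Carbamoylmethyl in place of isopropyl on a saturated chain carbon bound to an amide-type nitrogen and a carbonyl carbon gives a number 19.1 percentage points lower from compound 2 to compound 3 (beyond the scatter) in this assay, so isopropyl is now ahead of two different carbonyl-bearing groups at this position. Amino in place of benzyloxy on a carbonyl carbon gives a number 14 percentage points higher from compound 1 to compound 3 (beyond the scatter) in this assay, which shows that the end of that side chain also matters. Nothing available here accounts for either step. On these data alone, whether a carboxylic acid at that end would change the effect remains open. So does how a longer carbon chain or a cyclohexyl group would compare with isopropyl.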